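A few compounds are considered here, and "the series" means these few. Any claim that something is new, unique, unknown or untested is made for them only; others in the source may bear on it.

In an ADME assay on MDBK cells (Bos taurus) for cytotoxicity, read by MTT assay, with a stated time of 96 h (a lower number here means that less compound is tolerated, a higher number that more compound is tolerated), compound 1 `O=[N+]([O-])c1ccc(-c2nc3cc(C(F)(F)F)ccc3[nH]2)c([N+](=O)[O-])c1` gives 16000 nM. Compound 3 `CC(=O)Nc1ccc(-c2nc3cc(C(F)(F)F)ccc3[nH]2)cc1` gives 50000 nM. Compound 2 `CC(=O)Nc1ccc(-c2nc3ccccc3[nH]2)cc1` reaches only the limit of this assay, > 100000 nM.

Of the two numbers shown, compound 1 gives the lower and compound 3 the higher, a gap beyond the usual scatter. How the core of compound 1 differs from that of compound 3 is not broken down here.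

From compound 3 to compound 2 the change is hydrogen in place of trifluoromethyl on an aromatic carbon, and it gave an at least 2.0-fold higher number from compound 3 to compound 2 (0.30 log units; that floor lies within the scatter); the value of compound 2 sits at the limit of > 100000 nM in this assay, at which 1 of the 3 values shown sits, so only a floor for that step is known. Compound 4 `O=[N+]([O-])c1ccc(-c2nc3ccccc3[nH]2)c([N+](=O)[O-])c1` differs from compound 1 by the same change at the same place, (hydrogen in place of trifluoromethyl on an aromatic carbon). Compound 4 is therefore expected to give 40000 nM, between 16000 nM and 150000 nM. The expected step is a 2.5-fold higher number from compound 1 to compound 4 (0.40 log units; beyond the scatter), resting on the measured step of an at least 2.0-fold higher number from compound 3 to compound 2 (0.30 log units; that floor lies within the scatter), whose floor leaves room for a larger rise.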

Compound 4, half-maximal cytotoxic concentration: 20000 nM
Compound 4: middle estimate off by 2.0-fold (0.30 log units), on the high side; low and high end bracket the measured number.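

In this assay, hydrogen in place of trifluoromethyl on an aromatic carbon gave a 1.3-fold higher number from compound 1 to compound 4 (0.10 log units; within the scatter). Set beside the earlier case, the change has now been read on two cores, and the two steps cannot be ranked: the same change on two cores in this assay, an at least 2.0-fold higher number (0.30 log units; that floor lies within the scatter) from compound 3 to compound 2 and a 1.3-fold higher number (0.10 log units; within the scatter) from compound 1 to compound 4; the limit leaves it open whether they differ. This does not show that the step keeps its size from one core to the other, nor that it differs, as the value of compound 2 is a limit and not a number: the limit of > 100000 nM in this assay, at which 1 of the 4 values shown sits.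

As far as these compounds go, what a chlorine, an amine or a carboxylic acid would give in the same place stays open. For the compounds shown here, with only two pairs, it is also open how the change would behave on a third core.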